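Moving a Hydroxyl on One Ring of a Dienone

This account rests on a few compounds, and the source may have more. Where it says the series, first, only, none or still open, it means among the compounds named here.

Compound 1 `O=C(/C=C/c1ccc(O)c(O)c1)/C=C/c1ccccc1O` and compound 2 `O=C(/C=C/c1cccc(O)c1)/C=C/c1ccc(O)c(O)c1` share a core and differ by 3-hydroxyphenyl in place of 2-hydroxyphenyl on a double-bonded chain carbon bound to a double-bonded chain carbon. In a physicochemical assay for solubility, using the shake flask method, with a stated time of 12 h (a lower number here means a less soluble compound, a higher number a more soluble compound), compound 1 gives 111000 nM, while compound 2 gives 60000 nM, a step of a 1.9-fold lower number from compound 1 to compound 2 (0.27 log units; within the scatter). Compound 3 `O=C(/C=C/c1ccccc1O)/C=C/c1cccc(O)c1O` gives 151000 nM in this assay; the difference between its core and the core of compound 1 is not broken down here. Compound 4 `O=C(/C=C/c1cccc(O)c1)/C=C/c1cccc(O)c1O` has not yet been measured and differs from compound 3 by 3-hydroxyphenyl in place of 2-hydroxyphenyl on a double-bonded chain carbon bound to a double-bonded chain carbon, the same change as from compound 1 to compound 2. The expected step is a 1.9-fold lower number from compound 3 to compound 4 (0.28 log units; within the scatter), resting on the earlier step of a 1.9-fold lower number from compound 1 to compound 2 (0.27 log units; within the scatter), which stayed within the scatter. Compound 4 is therefore estimated at 80000 nM, with a likely range from 40000 nM to 160000 nM.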

Compound 4, solubility: 184000 nM
For compound 4 the middle estimate is 2.3-fold (0.36 log units) below the measured one; the measured number lies above the stated range.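

Placing 3-hydroxyphenyl where 2-hydroxyphenyl stood gives a 1.2-fold higher number from compound 3 to compound 4 (0.09 log units; within the scatter) in this assay and so stays within the scatter, as does a 1.9-fold lower number from compound 1 to compound 2 (0.27 log units; within the scatter) on the other core. The two steps point opposite ways on paper, but neither is large enough for its direction to be read, so what carries over between these two cores is only a step too small to interpret. This does not show that the step would stay as small on any other core, and nothing measured here offers an explanation for the result.

All the rings shown carry only hydroxyl groups. Going by these compounds, whether the same move stays as small with a methoxy group or an amine in place of the hydroxyl remains open.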